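This account rests on a few compounds, and the source may have more. Where it says the series, first, only, none or still open, it means among the compounds named here.

In an ADME assay on Vero 76 cells (Chlorocebus sabaeus) for cytotoxicity, read by crystal violet staining, with a stated time of 96 h (a lower number here means that less compound is tolerated, a higher number that more compound is tolerated), compound 1 (`FC(F)(F)c1cccc(NC(=S)Nc2ccc(Cl)cc2)c1`) gives 11000 nM. Compound 2 (`CC(=O)NC(=S)Nc1cccc(C(F)(F)F)c1`) gives > 100000 nM, which is a limit of the assay and not a number. Compound 2 therefore stands at the limit of > 100000 nM in this assay, at which 1 of the 2 values shown sits, so only a lower bound on its tolerated concentration is known.

The next compound, compound 3 (`CSCCCNC(=S)Nc1cccc(C(F)(F)F)c1`), carries 3-(methylsulfanyl)propyl in place of acetyl on an amide-type nitrogen. Within the data shown here, one measured step bears on this place, namely an at least 9.0-fold higher number from compound 1 to compound 2 (0.95 log units; beyond the scatter), with acetyl in place of 4-chlorophenyl on the same kind of nitrogen. That step is beyond the scatter and shows that a change here can move the read-out in this assay. Among the measured compounds shown here, no measured step covers the incoming chain itself.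

Compound 1 at 11000 nM serves as the lower reference, and a number for compound 3 is expected to fall short of that step's full size. The expected step is an at least 2.2-fold lower number from compound 2 to compound 3 (0.34 log units; beyond the scatter), and the assay may again report only a limit. For compound 3 the estimate is 45000 nM, with an expected range of 15000 nM to 100000 nM.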

Compound 3, half-maximal cytotoxic concentration: > 100000 nM
Compound 3 ended at the assay's limit; the forecaster's own chance of this, stated with the estimate: 35%; middle value at least 2.2-fold (0.34 log units) from the limit.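

Replacing 4-chlorophenyl on the amide-type nitrogen with 3-(methylsulfanyl)propyl in this assay gives an at least 9.0-fold higher number from compound 1 to compound 3 (0.95 log units; beyond the scatter), so the rise seen with acetyl, an at least 9.0-fold higher number from compound 1 to compound 2 (0.95 log units; beyond the scatter), is not unique to acetyl. Two different ring-free groups at this place now lead to the assay limit, and compound 1, the only compound shown with a ring on this nitrogen, is the only one with a readable number. The step from compound 2 to compound 3 cannot be read, and no order can be given for acetyl and 3-(methylsulfanyl)propyl, because both values are limits of the assay and not numbers: the limit of > 100000 nM in this assay, at which 2 of the 3 values shown sit.

Going by these compounds, how far compound 2 and compound 3 actually lie above compound 1 remains open, as does whether the sulfur in the chain of compound 3 has any bearing on the result. Also open, on these data alone, is whether a longer chain, a chain carrying an amine or a carboxylic acid, or an unsubstituted phenyl on the same amide-type nitrogen would stay at the limit or return a readable number.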